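From 3,4-Dimethylphenyl to 3,5-Dimethylphenyl on a Sulfonamide Nitrogen

The source may report more compounds than this note shows. Statements on the series, on what has been measured and on what is new or still open speak of the compounds shown alone.

Among the measured compounds shown here, in a functional assay on HT-29 cells (Homo sapiens) for antiproliferative activity, read by sulforhodamine B assay, with a stated time of 48 h (a lower number here means a stronger inhibitor, a higher number a weaker inhibitor), compound 1 (`Cc1ccc(NS(=O)(=O)c2ccc(N3CCNC3=O)cc2)cc1C`) gives 230 nM as the only true number available for this small set. Compound 2 (`CC(C)(C)c1ccc(NS(=O)(=O)c2ccc(N3CCNC3=O)cc2)cc1`) is reported as > 1000 nM and that entry is a limit of the assay, not a number. For the measured compounds named here, compound 1 is therefore the single measured point, and no step between two measured compounds can be read from these data.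

Compound 3 (`Cc1cc(C)cc(NS(=O)(=O)c2ccc(N3CCNC3=O)cc2)c1`) has yet to be measured. It carries 3,5-dimethylphenyl in place of 3,4-dimethylphenyl on a sulfonamide nitrogen, so the two compounds have the same atoms, joined differently. Going by the values given here, with no measured step to guide it, the expectation rests on compound 1 at 230 nM and on how small this change is. In this assay no shift beyond the usual scatter is expected, with at most a slight lean towards a weaker inhibitor. The expected step is a 1.3-fold higher number from compound 1 to compound 3 (0.12 log units; within the scatter) and it remains an estimate. For compound 3 the estimated value is 300 nM with an expected range from 100 nM to 900 nM in this estimate.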

Compound 3, half-maximal inhibitory concentration: 82 nM
Compound 3: the middle estimate sits 3.7-fold (0.56 log units) above what was measured; the measured number lies below the stated range.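

Moving one methyl group, while the atoms stay the same and the leaving and entering groups match in every count, gives a 2.8-fold lower number from compound 1 to compound 3 (0.45 log units; beyond the scatter) in this assay and so a first readable step at this position. Among the compounds shown here, with only one true number available before, the earlier compounds could not show that the aryl group on a sulfonamide nitrogen responds to the arrangement of its two methyl groups alone, with no change in what the group is made of. For the compounds shown here, compound 2 remains a limit of the assay and not a number, so no step involving it can be read: the limit of > 1000 nM in this assay, at which 1 of the 3 values shown sits.

The compounds shown leave open whether this difference belongs to the 3,5-dimethylphenyl arrangement in particular or would also appear with other groups on the same nitrogen, such as 3,5-dichlorophenyl, 3,5-dimethoxyphenyl or a phenyl ring carrying a single methyl group. They also leave open whether an amine or a carboxylic acid on that ring would be tolerated, and whether the step between these two isomers would hold in cells other than those of this one assay.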